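A few compounds are considered here, and "the series" means these few. Any claim that something is new, unique, unknown or untested is made for them only; others in the source may bear on it.

Working notes on the series. Compound 2 `COc1ccc(C2=C(c3cc(OC)c(OC)c(OC)c3)C(=O)C(O)C2)cc1NC(=O)c1ccccc1` is set against compound 1 `COCOc1cc(C2=C(c3cc(OC)c(OC)c(OC)c3)C(=O)CC2O[SiH2]C(C)(C)C)ccc1OC` and compound 3 `COc1ccc(OC)c(C2=C(c3cc(OC)c(OC)c(OC)c3)C(=O)CC2O)c1` in an ADME assay on HT-29 cells (Homo sapiens) for cytotoxicity, read by MTT assay, with a stated time of 72 h; on this read-out higher numbers stand for weaker inhibition and lower numbers for stronger inhibition. Compound 1 gives 43 ug/mL. Compound 3 reaches only the limit of the assay, > 100 ug/mL, and no number. Compound 2 likewise stops at the limit, > 100 ug/mL, which is the limit of > 100 ug/mL in this assay, at which 2 of the 3 values shown sit. Compound 2 therefore stands among the values without a number, with compound 1 the only measured figure. Among the measured compounds shown here, no step between two measured compounds is available in this assay. Compound 4 `COc1ccc(C2=C(c3cc(OC)c(OC)c(OC)c3)C(=O)C(O)C2)cc1OC(C)C` differs from compound 2 by isopropoxy in place of benzamido on an aromatic carbon. The step of an at least 1.1-fold lower number from compound 2 to compound 4 (0.04 log units; that floor lies within the scatter) is expected to stay within the scatter, with no clear direction. Compound 4 is estimated at 90 ug/mL in this assay, within a range from 40 ug/mL to 200 ug/mL, and a limit report remains likely.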

Compound 4, half-maximal inhibitory concentration: > 100 ug/mL
Compound 4: only a limit was reported; the forecaster's own chance of this, stated with the estimate: 55%; at least 1.1-fold (0.04 log units) between middle value and limit.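

Among the compounds shown here, compound 2 and compound 4 both stop at a limit of the assay, so no step between them can be read: the limit of > 100 ug/mL in this assay, at which 3 of the 4 values shown sit. The compounds shown leave open how isopropoxy and benzamido compare on this aromatic carbon.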